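The compounds below may be only part of what the source reports. "The series", "measured", "known", "first", "only" and "open" are said of these compounds alone.

Compound 2 `CO[C@@H]1OC[C@]2(C)CCC[C@]3(COC(=O)[C@@]45C[C@@H](CC[C@H]43)[C@H](C)C5=O)[C@H]12` is one of two measured members of this series. In a functional assay on K562 cells (Homo sapiens) for cytotoxicity, read by MTT assay (on this read-out lower numbers stand for stronger inhibition and higher numbers for weaker inhibition), compound 2 gives > 50 ug/mL, which is a limit of the assay and not a number. Going by the values given here, its only measured neighbour is compound 1 `CO[C@@H]1OC[C@]2(C)CCC[C@]3(COC(=O)[C@@]45C[C@@H](CC[C@H]43)[C@@H](C)C5=O)[C@H]12`. In this assay compound 1 gives > 50 ug/mL, again a limit. The step between them, a step that the two limits leave unreadable from compound 1 to compound 2, cannot be sized because of the limit of > 50 ug/mL in this assay, at which 2 of the 2 values shown sit; the pair is tied together by the fact that compounds 1 and 2 differ only in the configuration as drawn. Compound 3 `CO[C@H]1OC[C@]2(C)CCC[C@]3(COC(=O)[C@@]45C[C@@H](CC[C@H]43)[C@H](C)C5=O)[C@H]12` is the next member to be measured. Compared with compound 2, (the two compounds have the same atoms and bonds and differ only in configuration as drawn: 1 of 8 stereo elements differ; a stereocentre at a saturated ring carbon is drawn R in compound 2 and S in compound 3). Among the compounds with values here, the one measured step of the same kind gave no readable size, so nothing in the data points to compound 3 leaving the range where compound 2 sits. Compound 3 is therefore expected to give about 60 ug/mL, with a likely range from 30 ug/mL to 120 ug/mL. The expected step that the limit leaves unreadable from compound 2 to compound 3 is estimated to stay within the scatter.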

Compound 3, half-maximal inhibitory concentration: > 50 ug/mL
Compound 3 gave a limit, no number; the forecaster's own chance of this, stated with the estimate: 80%; the middle value lies beyond the limit too.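

Going by these compounds alone, no step among compound 1, compound 2 and compound 3 can be read in this assay, because all three give a limit and no number: the limit of > 50 ug/mL in this assay, at which 3 of the 3 values shown sit. The compounds shown leave open whether a change in drawn configuration alters the read-out in this assay at all.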